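Hexylamide series: hydroxy added to the aromatic ring

The source may report more compounds than this note shows. Statements on the series, on what has been measured and on what is new or still open speak of the compounds shown alone.

Measured so far:
compound 1, `O=C(O)/C=C/c1cc(O)c(O)c(O)c1`: > 200000 nM
compound 2, `CCCCCCNC(=O)/C=C/c1ccc(O)c(O)c1`: 56100 nM

In a functional assay on WiDr cells (Homo sapiens) for cytotoxicity, read by sulforhodamine B assay, with a stated time of 24 h (a lower number here means a stronger inhibitor, a higher number a weaker inhibitor), compound 1 gives > 200000 nM, a limit of the assay rather than a number; it sits at the limit of > 200000 nM in this assay, at which 1 of the 2 values shown sits. For the measured compounds named here, compound 2 is the only compound with a number in this assay, 56100 nM. Compound 3, `CCCCCCNC(=O)/C=C/c1cc(O)c(O)c(O)c1`, differs from compound 2 by hydroxy in place of hydrogen on an aromatic carbon. Going by the values given here, no measured pair shows this change, so no step size is known from the data. The step from compound 2 to compound 3 is expected to stay within the scatter, a 1.1-fold higher number from compound 2 to compound 3 (0.03 log units; within the scatter). Compound 3 is estimated at 60000 nM, in the range 25000 nM to 150000 nM.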

Compound 3, half-maximal inhibitory concentration: 71400 nM
The estimate for compound 3 lay 1.2-fold (0.08 log units) below the measured number; low and high end bracket the measured number.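

In this assay, hydroxy in place of hydrogen on this aromatic carbon, ortho to a hydroxy group, gives a 1.3-fold higher number from compound 2 to compound 3 (0.10 log units; within the scatter). This pair gives the series its first size for the change, and at this position the two hexylamides cannot be told apart in this assay. For the compounds shown here, compound 1 stays a limit of the assay and not a number, so no step to it can be read: the limit of > 200000 nM in this assay, at which 1 of the 3 values shown sits.

Still open, on these data alone, is whether a methoxy group or an amine on this aromatic carbon would give a step beyond the scatter. The same holds for a longer chain on the amide nitrogen.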